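From Compound 3 to Compound 4: A Halogen Swap

The source may report more compounds than this note shows. Statements on the series, on what has been measured and on what is new or still open speak of the compounds shown alone.

In a functional assay on PC-3 cells (Homo sapiens) for cytotoxicity, read by MTT assay, with a stated time of 72 h (a higher number here means a weaker inhibitor, a lower number a stronger inhibitor), compound 1 `O=C(N/N=C/c1ccc(F)cc1)Nc1cc2c(Nc3ccc(F)c(Cl)c3)ncnc2cc1O[C@H]1CCOC1` is reported as "not active" (no number reported) with no number attached. Compound 3 `O=C(N/N=C/c1ccc(F)cc1Cl)Nc1cc2c(Nc3ccc(F)c(Cl)c3)ncnc2cc1O[C@H]1CCOC1` gives 28400 nM and stands level with compound 2 `O=C(N/N=C/c1ccc([N+](=O)[O-])cc1)Nc1cc2c(Nc3ccc(F)c(Cl)c3)ncnc2cc1O[C@H]1CCOC1`, which gives 33500 nM as its own reading. Within the data shown here, the step of a 1.2-fold lower number from compound 2 to compound 3 (0.07 log units; within the scatter) is the only measured one in this small set, so compound 3 cannot be ranked apart from its one numbered neighbour.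

Compound 4 `O=C(N/N=C/c1cccc(Cl)c1Cl)Nc1cc2c(Nc3ccc(F)c(Cl)c3)ncnc2cc1O[C@H]1CCOC1` has not been measured yet. It differs from compound 3 by a single change, with 2,3-dichlorophenyl in place of 2-chloro-4-fluorophenyl on a carbon with a double bond to nitrogen while the rest of the structure stays the same.

The measured step bears on this directly, since it changed the group at that same place and left the number within the scatter. One step is thin evidence, however. Compound 1 stands against any rule that this group never matters: it yielded no number at all.

No shift beyond the scatter is therefore expected in this assay for this swap. The expected step is a 1.1-fold higher number from compound 3 to compound 4 (0.02 log units; within the scatter) and it is estimated to carry no clear direction. Compound 4 is estimated at 30000 nM with an expected range from 15000 nM to 60000 nM if a number is reported at all.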

Compound 4, half-maximal inhibitory concentration: 27400 nM
Compound 4: the middle estimate sits 1.1-fold (0.04 log units) above what was measured; measured number inside the range.
By their numbers in this assay, from the lowest: compounds 4, 3 and 2 (each within the scatter of the next).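

In this assay, the step of a 1.0-fold lower number from compound 3 to compound 4 (0.02 log units; within the scatter) shows that trading the fluorine of the 2-chloro-4-fluorophenyl group for a second chlorine, in the 2,3-dichlorophenyl group, leaves the reading within the scatter. The step of a 1.2-fold lower number from compound 2 to compound 4 (0.09 log units; within the scatter) adds a second comparison for the new group, this time against 4-nitrophenyl, and it too stays within the scatter. Among these compounds, three different rings on the carbon with a double bond to nitrogen now give readings that cannot be told apart, which is more than the single earlier step could show, although this flat pattern covers only compounds 2, 3 and 4, and compound 1, with its 4-fluorophenyl group, goes against it by giving "not active" (no number reported).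

Nothing shown here explains why these three groups read alike or why compound 1 gives no number. Going by these compounds, it also remains open whether an amine or a carboxylic acid on the ring, or a longer chain in place of the ring, would move the number beyond the scatter.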